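The source may report more compounds than this note shows. Statements on the series, on what has been measured and on what is new or still open speak of the compounds shown alone.

Compound 1 `Cc1ccc(S(=O)(=O)c2nc3ccccc3nc2Nc2ccc(Cl)cc2)cc1` and compound 2 `Cc1ccc(S(=O)(=O)c2nc3ccccc3nc2Nc2ccc(C(F)(F)F)cc2)cc1` share one core and differ only by trifluoromethyl in place of chloro on an aromatic carbon. In a functional assay on PC-3 cells (Homo sapiens) for cytotoxicity, read by MTT assay, with a stated time of 72 h (on this read-out higher numbers stand for weaker inhibition and lower numbers for stronger inhibition), compound 1 gives 9660 nM, and compound 2 gives 2540 nM, a change of a 3.8-fold lower number from compound 1 to compound 2 (0.58 log units; beyond the scatter). Compound 3 `COc1ccc(S(=O)(=O)c2nc3ccccc3nc2Nc2ccc(Cl)cc2)cc1` differs from compound 1 in its core by methoxy in place of methyl on an aromatic carbon, and in this assay compound 3 gives 31800 nM, a change of a 3.3-fold higher number from compound 1 to compound 3 (0.52 log units; beyond the scatter). Compound 4 `COc1ccc(S(=O)(=O)c2nc3ccccc3nc2Nc2ccc(C(F)(F)F)cc2)cc1` carries the same change relative to compound 3, (trifluoromethyl in place of chloro on an aromatic carbon), at the same place as seen from compound 1 to compound 2. Within the data shown here, the step from compound 3 to compound 4 in this assay is expected to be a 3.5-fold lower number from compound 3 to compound 4 (0.55 log units; beyond the scatter), resting on the single earlier example a 3.8-fold lower number from compound 1 to compound 2 (0.58 log units; beyond the scatter) transferred onto the core of compound 3. Compound 4 is therefore estimated at 9000 nM, likely between 3500 nM and 25000 nM.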

Compound 4, half-maximal inhibitory concentration: 330 nM
The estimate for compound 4 lay 27-fold (1.44 log units) above the measured number; the whole stated range lies above it.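

The change from chloro to trifluoromethyl does not carry from one core to another as a fixed step in this assay, as a 96-fold lower number from compound 3 to compound 4 (1.98 log units; beyond the scatter) is far larger than the step seen on the core of compound 1: the same change on two cores in this assay, a 3.8-fold lower number (0.58 log units; beyond the scatter) from compound 1 to compound 2 and a 96-fold lower number (1.98 log units; beyond the scatter) from compound 3 to compound 4, 25-fold (1.40 log units) apart, beyond the scatter of two such steps. The change from methyl to methoxy even reverses direction, with a 7.7-fold lower number from compound 2 to compound 4 (0.89 log units; beyond the scatter), whereas it raised the number on the chloro pair: the same change on two cores in this assay, a 3.3-fold higher number (0.52 log units; beyond the scatter) from compound 1 to compound 3 and a 7.7-fold lower number (0.89 log units; beyond the scatter) from compound 2 to compound 4, 25-fold (1.40 log units) apart, beyond the scatter of two such steps. So in these four compounds the effect of a change at one place depends on the group at the other, but this does not show why, or whether it holds beyond them.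

Going by these compounds, it remains open whether a nitrile or an amine in place of trifluoromethyl would show the same dependence. On these data alone, an ethoxy group in place of methoxy is equally open.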